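A few compounds are considered here, and "the series" means these few. Any claim that something is new, unique, unknown or untested is made for them only; others in the source may bear on it.

Compound 1 `Cc1cc(C(=O)Nc2ccccn2)nn1Cc1cc(Cl)ccc1OCc1ccccc1` carries a (pyridin-2-yl)carbamoyl group on its five-membered core. In a physicochemical assay for lipophilicity, at pH 7.4 (on this read-out higher numbers stand for higher lipophilicity and lower numbers for lower lipophilicity), compound 1 gives > 3.7, which is a limit of the assay rather than a number. Compound 2 `Cc1cc(NC(=O)C2CCCCC2)nn1Cc1cc(Cl)ccc1OCC(C)C` gives > 3.7 in this assay, again a limit. Compound 3 `Cc1cc(NC(=O)OC(C)(C)C)nn1Cc1cc(Cl)ccc1OCc1ccccc1` gives > 3.7 in this assay, also a limit. Within the data shown here, the only measured step that differs in one place, a step that the two limits leave unreadable from compound 1 to compound 3, therefore tells nothing about its size. All that is known is the limit of > 3.7 in this assay, at which 3 of the 3 values shown sit.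

Compound 4 `Cc1cc(NC(=O)OCC(C)C)nn1Cc1cc(Cl)ccc1OCc1ccccc1` differs from compound 1 in one place: (isobutoxycarbonyl)amino in place of (pyridin-2-yl)carbamoyl on an aromatic carbon. Among the measured compounds shown here, the change resembles the one in a step that the two limits leave unreadable from compound 1 to compound 3, which the two limits leave unreadable, so no measured step gives a usable size or direction. Compound 4 is nevertheless expected to give 4.4 in this assay, with a range from 3.7 to 5.2, most likely again as a limit. The expected step is a step that the limit leaves unreadable from compound 1 to compound 4.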

Compound 4, distribution coefficient: 3.3
Compound 4: middle estimate off by 1.10 log units, on the high side; measured number outside the range, below it.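

Putting (isobutoxycarbonyl)amino in place of (pyridin-2-yl)carbamoyl on an aromatic carbon of the shared core gives, in this assay, a number at least 0.40 log units lower from compound 1 to compound 4 (beyond the scatter). The second comparison is narrower: with isobutyl in place of tert-butyl on an oxygen next to a carbonyl group, and the rest of the molecule unchanged, this assay shows a number at least 0.40 log units lower from compound 3 to compound 4 (beyond the scatter), so a change within this side chain alone is enough to move the read-out. Both steps give only a minimum size, and compound 4 is the one compound here with a readable number: the limit of > 3.7 in this assay, at which 3 of the 4 values shown sit.

As far as these compounds go, how the read-out would respond to a shorter chain such as ethyl, or to a carboxylic acid or a morpholine at this position, remains open. Also open, from the compounds shown here alone, is whether isobutyl in place of tert-butyl would give a similar step on a different core.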